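The source may report more compounds than this note shows. Statements on the series, on what has been measured and on what is new or still open speak of the compounds shown alone.

Among these four compounds, three have been tested in an assay on isolated protein for antagonist activity at Bile acid receptor (Homo sapiens), read by HTRF, with a stated time of 30 min; on this read-out higher numbers stand for weaker inhibition and lower numbers for stronger inhibition. Compound 1 `CC(C)(C)c1cc(NC(=O)c2ccc(Cl)cc2Cl)cc(C(C)(C)C)c1O` gives only a limit there, > 100000 nM, not a number. Compound 2 `COc1ccc(NC(=O)c2ccc(Cl)cc2Cl)cc1C(C)(C)C` likewise reaches only the limit of > 100000 nM. Within the data shown here, compound 3 `CC(C)(C)c1cc(NC(=O)c2c(Cl)cc(NCc3ccncc3)cc2Cl)ccc1O` gives 9800 nM in this assay, the only measured number among the three. Compound 3 thus stands apart from the limit of > 100000 nM in this assay, at which 2 of the 3 values shown sit. Compound 4 `CC(C)(C)c1cc(NC(=O)c2c(Cl)cc(NC3CCCCC3)cc2Cl)ccc1O` has not been measured yet. It differs from compound 3 in one place: cyclohexyl in place of (pyridin-4-yl)methyl on a nitrogen on an aromatic ring. Among the measured compounds shown here, no measured pair of this kind exists to lean on. The step is expected to be small, a 1.2-fold lower number from compound 3 to compound 4 (0.09 log units; within the scatter), and may well fall within the usual scatter. Compound 4 is therefore estimated at 8000 nM, with a range from 2000 nM to 40000 nM.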

Compound 4, half-maximal inhibitory concentration: 2500 nM
The estimate for compound 4 lay 3.2-fold (0.51 log units) above the measured number, within the range that was stated.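

In this assay cyclohexyl on this nitrogen gives a 3.9-fold lower number from compound 3 to compound 4 (0.59 log units; beyond the scatter) and so a modest gain in inhibition over (pyridin-4-yl)methyl. This pair shows that the position accepts a non-aromatic ring of carbon only, and that the aromatic ring with its hetero atom is not needed for inhibition here. Nothing shown explains why the step runs in this direction.

Going by these compounds, whether a small methyl, a longer chain or a ring carrying an amine would do better on this nitrogen stays open. So does which part of the change matters: the ring itself, its nitrogen, or the link to the amine.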